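Swapping a cyclopentyl for a hydroxyethyl chain on the amine

This account rests on a few compounds, and the source may have more. Where it says the series, first, only, none or still open, it means among the compounds named here.

Measured compounds:
- compound 1, `CNc1nc(-c2ccccc2)nc2c1nnn2Cc1ccccc1Cl`: 191000000 nM
- compound 2, `OCCCNc1nc(-c2ccccc2)nc2c1nnn2Cc1ccccc1Cl`: 33000000 nM
- compound 3, `c1ccc(Cn2nnc3c(NC4CCCC4)nc(-c4ccccc4)nc32)cc1`: 11000000 nM

All three share one core and differ at the amine attached to it and at the benzyl group. In an assay on isolated protein for binding affinity to adenosine receptor A1 (Bos taurus) (on this read-out lower numbers stand for stronger inhibition and higher numbers for weaker inhibition), compound 3 gives the lowest number of the three, and its gaps to compound 2 and to compound 1 are both beyond the scatter, so it is the strongest binder here.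

Compound 4, `OCCNc1nc(-c2ccccc2)nc2c1nnn2Cc1ccccc1`, differs from compound 3 in one place: 2-hydroxyethyl in place of cyclopentyl on a nitrogen on an aromatic ring. For the measured compounds named here, no measured step repeats exactly this swap. The nearest guide is the step of a 5.8-fold lower number from compound 1 to compound 2 (0.76 log units; beyond the scatter), which shows that a hydroxyl-bearing chain on this nitrogen is tolerated and even helps next to a bare methyl. Compound 2, which carries a hydroxypropyl chain, and compound 3, which carries cyclopentyl, differ in two places, so their values can only be compared directly: compound 3 sits lower.

On that basis compound 4 is expected to bind somewhat more weakly than compound 3, a step of about a 3.6-fold higher number from compound 3 to compound 4 (0.56 log units; beyond the scatter) in this assay, with an estimated value of 40000000 nM and a range from 10000000 nM to 150000000 nM.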

Compound 4, inhibition constant: 38000000 nM
Beside the measured number, compound 4's estimate is 1.1-fold (0.02 log units) above it; the range from low to high includes it.
By their numbers in this assay, from the lowest: compound 3; then compounds 2 and 4 (each within the scatter of the next); then compound 1.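

For the compounds shown here, compound 3 and compound 4 differ only at the amine, which gives the first direct reading of cyclopentyl against a hydroxyl-bearing chain on this nitrogen: in this assay, replacing cyclopentyl with 2-hydroxyethyl gives a 3.5-fold higher number from compound 3 to compound 4 (0.54 log units; beyond the scatter). The earlier step, a 5.8-fold lower number from compound 1 to compound 2 (0.76 log units; beyond the scatter), showed only that a hydroxyl-bearing chain can beat a bare methyl on a different benzyl group; the new step shows that a 2-hydroxyethyl chain does not match cyclopentyl on the plain benzyl group, so the benefit seen with the hydroxyl-bearing chain does not extend to every comparison at this position. The swap removes a five-membered ring of carbon and adds a hydrogen-bond donor and acceptor in a single change, and nothing measured here explains why the number rises.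

Still open, going by these compounds, is whether losing the ring or adding the hydroxyl matters more: a plain propyl chain would have neither ring nor hydroxyl, while a hydroxycyclopentyl group would have both. Also open, on these data alone, is whether the same swap would give a step of similar size on the chlorine-bearing benzyl group of compound 1.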